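Chloro to methyl on the phenyl group of compound 2

A few compounds are considered here, and "the series" means these few. Any claim that something is new, unique, unknown or untested is made for them only; others in the source may bear on it.

In a functional assay on K562 cells (Homo sapiens) for cytotoxicity, in the presence of a further agent that is not named here (on this read-out lower numbers stand for stronger inhibition and higher numbers for weaker inhibition), compound 2 (`Clc1ccc(-c2cc(-c3ccc(Cl)o3)cc(-c3ccsc3)n2)cc1`) gives 18700 nM and compound 1 (`Clc1ccc(-c2cc(-c3ccsc3)nc(-c3ccccc3Cl)c2)o1`) gives 17200 nM as its nearest neighbour. These two numbers lie within the scatter of each other and form the high end of the series. Compound 3 (`Clc1ccc(-c2cc(-c3ccoc3)cc(-c3ccsc3)n2)cc1`) gives 730 nM at the low end.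

Compound 4 (`Cc1ccc(-c2cc(-c3ccc(Cl)o3)cc(-c3ccsc3)n2)cc1`) differs from compound 2 at one place: methyl in place of chloro on an aromatic carbon, with methyl in place of chloro on an aromatic carbon.

Among the compounds with values here, two measured steps bear on this. The step of a 1.1-fold higher number from compound 1 to compound 2 (0.04 log units; within the scatter) shifts the chloro on the phenyl group and stays small. The step of a 26-fold lower number from compound 2 to compound 3 (1.41 log units; beyond the scatter) is large, but it concerns the furan group, not the site of the present change. Within the data shown here, no measured step replaces chloro with methyl, so no change beyond the scatter is expected in this assay, and neither direction is favoured.

The expected step is a 1.1-fold lower number from compound 2 to compound 4 (0.04 log units; within the scatter) as estimated here. For compound 4 the estimated value is 17000 nM, with an expected range from 7000 nM to 40000 nM.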

Compound 4, half-maximal inhibitory concentration: 19900 nM
For compound 4 the middle estimate is 1.2-fold (0.07 log units) below the measured one, and the stated range covers the measured number.
By their numbers in this assay, from the lowest: compound 3; then compounds 1, 2 and 4 (each within the scatter of the next).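

In this assay, within the data shown here, methyl in place of chloro on the phenyl group gives a 1.1-fold higher number from compound 2 to compound 4 (0.03 log units; within the scatter), the first direct reading of this swap at this site, para to a large group, and it does not separate the two substituents. With a 1.2-fold higher number from compound 1 to compound 4 (0.06 log units; within the scatter), where 4-methylphenyl replaces 2-chlorophenyl, compounds 1, 2 and 4, all carrying 5-chlorofuran-2-yl, remain within the scatter of each other, so neither of these substituent changes on the phenyl group has yet moved the number. No measured information is available to explain this flat result.

Open, on these data alone, is whether an amine, a carboxylic acid or a longer chain at this site would shift the number. Also open, as far as these compounds go, is whether the chloro-to-methyl swap reads the same with furan-3-yl, as in compound 3 at 730 nM.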